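Two pyridine-linked phenols, one furan swap still to be measured

A few compounds are considered here, and "the series" means these few. Any claim that something is new, unique, unknown or untested is made for them only; others in the source may bear on it.

Measured compounds:
compound 1, `Oc1cccc(-c2cc(-c3ccc(Cl)cc3)nc(-c3ccccn3)c2)c1`, 8090 nM
compound 2, `Oc1cccc(-c2cc(-c3ccc(Cl)cc3)nc(-c3ccco3)c2)c1`, 11400 nM
compound 3, `Oc1ccc(-c2cc(-c3ccc(Cl)cc3)nc(-c3ccccn3)c2)cc1`, 22500 nM

Of the compounds shown here, three sharing one core have been tested in a functional assay on DU-145 cells (Homo sapiens) for cytotoxicity, read by CCK-8 assay and cell counting, with a stated time of 2 days; on this read-out lower numbers stand for stronger inhibition and higher numbers for weaker inhibition. Compound 1 gives 8090 nM in this assay, and compound 2, which carries furan-2-yl in place of pyridin-2-yl on an aromatic carbon, gives 11400 nM; the step between them, a 1.4-fold higher number from compound 1 to compound 2 (0.15 log units; within the scatter), is small. Within the data shown here, compound 3 differs from compound 1 by 4-hydroxyphenyl in place of 3-hydroxyphenyl on an aromatic carbon; in this assay compound 3 gives 22500 nM, so that a 2.8-fold higher number from compound 1 to compound 3 (0.44 log units; beyond the scatter) is the only step here that reaches beyond the scatter. Compound 2 and compound 3 are not joined by a single change, and their two values lie close to each other.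

Compound 4, `Oc1ccc(-c2cc(-c3ccc(Cl)cc3)nc(-c3ccco3)c2)cc1`, has not yet been measured. It differs from compound 3 by furan-2-yl in place of pyridin-2-yl on an aromatic carbon. Among the measured compounds shown here, this is the same kind of change as the one from compound 1 to compound 2, though the surroundings are not identical: in compound 1 the place is meta to a 3-hydroxyphenyl group, whereas in compound 3 it is meta to a 4-hydroxyphenyl group. Because a 1.4-fold higher number from compound 1 to compound 2 (0.15 log units; within the scatter) was small, the corresponding step for compound 4 is expected to be small as well, a 1.3-fold higher number from compound 3 to compound 4 (0.12 log units; within the scatter) in this assay. On that basis compound 4 is estimated at 30000 nM in this assay, with a likely span from 12000 nM to 80000 nM.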

Compound 4, half-maximal inhibitory concentration: 7280 nM
For compound 4 the middle estimate is 4.1-fold (0.61 log units) above the measured one; measured number outside the range, below it.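

In this assay, furan-2-yl in place of pyridin-2-yl gives a 3.1-fold lower number from compound 3 to compound 4 (0.49 log units; beyond the scatter), so the change that made little difference on the core of compound 1 does not behave the same way on the core of compound 3: the same change on two cores in this assay, a 1.4-fold higher number (0.15 log units; within the scatter) from compound 1 to compound 2 and a 3.1-fold lower number (0.49 log units; beyond the scatter) from compound 3 to compound 4, 4.4-fold (0.64 log units) apart, beyond the scatter of two such steps. The hydroxyl shift shows the same dependence, since 4-hydroxyphenyl in place of 3-hydroxyphenyl gives a 1.6-fold lower number from compound 2 to compound 4 (0.19 log units; within the scatter) when furan-2-yl is present, which does not repeat the earlier step made with pyridin-2-yl: the same change on two cores in this assay, a 2.8-fold higher number (0.44 log units; beyond the scatter) from compound 1 to compound 3 and a 1.6-fold lower number (0.19 log units; within the scatter) from compound 2 to compound 4, 4.4-fold (0.64 log units) apart, beyond the scatter of two such steps. Within these four compounds, therefore, neither change can be carried from one core to the other as a fixed step, although this rests on a single pair of steps for each change and shows neither why the two groups depend on each other nor how far that dependence extends.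

The compounds shown leave open whether the same dependence would appear with thiophen-2-yl in place of furan-2-yl, or with a methoxy group or an amine in place of the hydroxyl. They also leave open how either change would behave if the 4-chlorophenyl group, present throughout, gave way to another group such as an unsubstituted phenyl.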